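Swapping an Aminophenyl for a Dichlorophenyl on the Carbonyl

The source may report more compounds than this note shows. Statements on the series, on what has been measured and on what is new or still open speak of the compounds shown alone.

Measured so far in a functional assay on NCI-H522 cells (Homo sapiens) for cytotoxicity, read by sulforhodamine B assay, with a stated time of 48 h, tested at 0.01 uM; on this read-out lower numbers stand for a stronger effect and higher numbers for a weaker effect at the one concentration tested:
compound 1, `COc1cc(-c2cc(/C=C/C(=O)c3ccc(N)cc3)[nH]n2)cc(OC)c1OC`, gives 92%
compound 2, `COc1ccc(-c2cc(/C=C/C(=O)c3ccc(OC)c(OC)c3)[nH]n2)cc1`, gives 102%

Compound 1 has the lower of these two numbers, yet compound 2 lies within the usual scatter of it, so the two cannot be told apart. Both numbers sit near the untreated level, meaning the cells were barely affected at this concentration. Compound 3, `COc1cc(-c2cc(/C=C/C(=O)c3ccc(Cl)c(Cl)c3)[nH]n2)cc(OC)c1OC`, is not yet measured. It differs from compound 1 by 3,4-dichlorophenyl in place of 4-aminophenyl on a carbonyl carbon. For the measured compounds named here, no step between measured compounds exists to calibrate this change, so no shift beyond the scatter is expected in this assay. The step of a number 3 percentage points higher from compound 1 to compound 3 (within the scatter) is estimated to be small. Compound 3 is expected to give 95%, between 80% and 110%.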

Compound 3, a percentage reported as activity, at one concentration (the size of the read-out at that concentration, not a potency): 92%
Compound 3: the middle estimate sits 3 percentage points above what was measured, and the stated range covers the measured number.
By their numbers in this assay, from the lowest: compounds 1, 3 and 2 (each within the scatter of the next).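

Replacing 4-aminophenyl with 3,4-dichlorophenyl on the carbonyl carbon gives no change at the digits printed from compound 1 to compound 3 (within the scatter) in this assay. This single-place step shows that, at this one concentration, losing the amine and gaining two chlorines leaves the read-out unmoved, with both compounds still close to the untreated level. Nothing measured here explains this result. Going by these compounds, whether a carboxylic acid or a morpholine at this position would shift the number remains open, and so does whether this exchange would matter at other concentrations.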